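A few compounds are considered here, and "the series" means these few. Any claim that something is new, unique, unknown or untested is made for them only; others in the source may bear on it.

In a functional assay on HeLa cells (Homo sapiens) for antiproliferative activity, read by cell counting, with a stated time of 72 h (on this read-out lower numbers stand for stronger inhibition and higher numbers for weaker inhibition), compound 1 `C#C[C@@]1(O)[C@@H](CO)O[C@@H](n2cnc3c(-c4ccc(C)cc4)ncnc32)[C@@H]1O` gives only a limit, > 250000 nM, and not an exact number. Among the measured compounds shown here, compound 2 `C#C[C@@]1(O)[C@@H](CO)O[C@@H](n2cnc3c(-c4ccc(F)cc4)ncnc32)[C@@H]1O` gives 220000 nM, whereas compound 3 `C#C[C@@]1(O)[C@@H](CO)O[C@@H](n2cc(F)c3c(N)ncnc32)[C@@H]1O` gives 150 nM, the lowest number so far and far beyond the scatter from compound 2.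

Compound 4 `C#Cc1cn([C@@H]2O[C@H](CO)[C@](O)(C#C)[C@H]2O)c2ncnc(N)c12` has not yet been measured and differs from compound 3 in one place: ethynyl in place of fluoro on an aromatic carbon. The swap, ethynyl in place of fluoro, sits on an aromatic carbon of a five-membered aromatic ring with 1 nitrogen.

For the measured compounds named here, only one measured step involves a single change, an at least 1.1-fold lower number from compound 1 to compound 2 (0.05 log units; that floor lies within the scatter). It also involves fluoro on an aromatic carbon, but at a different site, and it rests on a limit, so it offers little guidance on size or direction. Starting from compound 3 at 150 nM, a moderate loss of potency in this assay is a cautious expectation, with much uncertainty. The expected change is a 4.0-fold higher number from compound 3 to compound 4 (0.60 log units; beyond the scatter). For compound 4 the estimated value is 600 nM, within an expected range of 60 nM to 10000 nM.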

Compound 4, half-maximal inhibitory concentration: 114000 nM
Estimate against measurement, compound 4: 190-fold (2.28 log units) below; measured number above the stated range.
By their numbers in this assay, from the lowest: compound 3; then compounds 4 and 2 (each within the scatter of the next). At a limit, above all of these: compound 1.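

In this assay, the aromatic carbon of the five-membered ring proves highly sensitive to what it carries: ethynyl in place of fluoro gives a 760-fold higher number from compound 3 to compound 4 (2.88 log units; beyond the scatter). Among the compounds shown here, a change of just two carbons for one fluorine at this carbon is therefore enough to remove nearly all of the potency seen with fluoro, something the earlier compounds, which changed only a distant site, could not reveal. Unlike the earlier step, this one joins two exact numbers, so its full size can be read, while compound 1 alone stands at a limit: the limit of > 250000 nM in this assay, at which 1 of the 4 values shown sits.

On these data alone, whether the loss belongs to ethynyl in particular or would follow any replacement for fluoro remains open. The compounds shown do not tell how a chlorine, a nitrile or an aminomethyl group would fare on this carbon.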